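This account rests on a few compounds, and the source may have more. Where it says the series, first, only, none or still open, it means among the compounds named here.

Compound 1 `CC1=CC[C@H](C(C)(C)NC(=S)N/N=C/c2ccc(O)cc2)CC1` and compound 2 `COc1cc(/C=N/NC(=S)NC(C)(C)[C@H]2CC=C(C)CC2)ccc1O` differ in one place: methoxy in place of hydrogen on an aromatic carbon. In a functional assay on K562 cells (Homo sapiens) for inhibition, read by sulforhodamine B assay, with a stated time of 48 h (on this read-out higher numbers stand for weaker inhibition of growth and lower numbers for stronger inhibition of growth), compound 1 gives only a limit, > 100000 nM. Compound 2 gives 1900 nM. That step is an at least 52-fold lower number from compound 1 to compound 2 (1.72 log units; beyond the scatter), and its true size is open, as the limit of > 100000 nM in this assay, at which 2 of the 3 values shown sit, sets the starting point.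

Compound 3 `CC1=CC[C@H](C(C)(C)NC(=S)N/N=C(\C)c2ccccc2)CC1` has another core; the difference between the two cores is not broken down here. In this assay compound 3 also gives only a limit, > 100000 nM. Compound 4 `COc1ccc(/C(C)=N/NC(=S)NC(C)(C)[C@H]2CC=C(C)CC2)cc1` is still to be measured and shows the same kind of change: methoxy in place of hydrogen on an aromatic carbon. The place is not the same as in compound 2, where the methoxy stands ortho to a hydroxy group and meta to a large group. Resting on the earlier step of an at least 52-fold lower number from compound 1 to compound 2 (1.72 log units; beyond the scatter) but weighed against that difference in place, the expected step is an at least 2.5-fold lower number from compound 3 to compound 4 (0.39 log units; beyond the scatter). Compound 4 is estimated to give about 40000 nM, expected between 5000 nM and 150000 nM.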

Compound 4, concentration for 50% growth inhibition: 54000 nM
Compound 4: the middle estimate sits 1.4-fold (0.13 log units) below what was measured; low and high end bracket the measured number.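

Carried to the core of compound 3, with phenyl becoming 4-methoxyphenyl, the change gives an at least 1.8-fold lower number from compound 3 to compound 4 (0.26 log units; that floor lies within the scatter). Compound 3 gives only a limit, > 100000 nM. A lower number on both cores fits the change carrying over, but this does not show that it does so to the same extent, and the methoxy also stands in a different place in each pair: the same change on two cores in this assay, an at least 52-fold lower number (1.72 log units; beyond the scatter) from compound 1 to compound 2 and an at least 1.8-fold lower number (0.26 log units; that floor lies within the scatter) from compound 3 to compound 4; the limit leaves it open whether they differ

The compounds shown leave open how the methoxy would act at other places on the ring of compound 4. They also leave open whether another group in its place, such as an amine or a carboxylic acid, would give a lower or a higher number in this assay.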